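The source may hold more compounds than are shown below. What is called first, only, known or untested is meant among the compounds shown, and "the series" means these compounds.

Working notes on the series: three compounds sharing one core have entries in an ADME assay on a cell-free system (plasma, Rattus norvegicus) (a higher number here means a larger unbound share of the compound, a lower number a smaller unbound share), and only one of them carries a number. Compound 1 (`COCCN(C)S(=O)(=O)c1ccc(C)c(C#Cc2cc(Cl)ccc2OCC(=O)O)c1`) gives 0.007. Compound 2 (`CC(C)S(=O)(=O)c1ccc(Cl)c(C#Cc2cc(Cl)ccc2OCC(=O)O)c1`) stands at "not determined" (no result reported). Compound 3 (`COCCNS(=O)(=O)c1ccc(C)c(C#Cc2cc(Cl)ccc2OCC(=O)O)c1`) also stands at "not determined" (no result reported), so it has no place on the scale and offers no number to start from.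

Next in this assay is compound 4 (`Cc1ccc(S(=O)(=O)N(C)C)cc1C#Cc1cc(Cl)ccc1OCC(=O)O`). Its structural change from compound 3 is dimethylamino in place of (2-methoxyethyl)amino on a sulfonyl sulfur, with the rest of the structure unchanged.

Among the compounds with values here, no measured step shows what a change on the sulfonyl sulfur does to the unbound share, and the missing value for compound 3 means that the step to compound 4 will not be calculable from this result either. Within the data shown here, the only anchor is compound 1 at 0.007. Compound 4 is expected to stay close to that low number, with no shift beyond the usual scatter in either direction. The range is kept wide, since it rests on a single measured value.

For compound 4, the estimated unbound fraction is 0.008, with an expected range of 0.003 to 0.02.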

Compound 4, unbound fraction: 0.004
Estimate against measurement, compound 4: 2.0-fold (0.30 log units) above; measured number inside the range.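

In this assay, within the data shown here, the step of a 1.8-fold lower number from compound 1 to compound 4 (0.24 log units; within the scatter) is the first readable step at the sulfonamide nitrogen substituents, and it lies within the scatter. With hydrogen in place of methoxymethyl on the saturated chain carbon bound to the sulfonamide nitrogen, the pair therefore shows no separable effect of this change, and both compounds remain at a low unbound share; the step from compound 3 to compound 4 cannot be read. Nothing available bears on why the unbound share behaves this way.

Still open, going by these compounds, is whether any group on the sulfonyl sulfur can move the unbound share beyond the scatter, since this pair covers only two closely related tertiary sulfonamides, and a morpholine ring or a longer chain ending in a hydroxyl group would test that more widely. Also open, on these data alone, is what the hydrogen on the sulfonamide nitrogen of compound 3 does to the unbound share, as well as whether the isopropyl sulfone and chloro pattern of compound 2 sits anywhere near these low numbers.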